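From a Hydroxyethyl Amine to a Cyclohexyl Methyl Amine

The source may report more compounds than this note shows. Statements on the series, on what has been measured and on what is new or still open speak of the compounds shown alone.

Measured in a functional assay on MCF7 cells (Homo sapiens) for antiproliferative activity; on this read-out lower numbers stand for stronger inhibition and higher numbers for weaker inhibition:
- compound 1 `CC(C)=CCc1cc(C(=O)Nc2cc3ccc(OCCCNC(C)(C)C)c(C)c3oc2=O)ccc1O` gives 950 nM
- compound 2 `CC(C)=CCc1cc(C(=O)Nc2cc3ccc(OCCCNCCO)c(C)c3oc2=O)ccc1O` gives 1560 nM

Compound 2 stands within the scatter of compound 1, so these two numbers cannot be told apart. The next compound, compound 3 `CC(C)=CCc1cc(C(=O)Nc2cc3ccc(OCCCN(C)C4CCCCC4)c(C)c3oc2=O)ccc1O`, differs from compound 2 as follows: cyclohexyl(methyl)amino in place of (2-hydroxyethyl)amino on a saturated chain carbon, three bonds along the chain from an oxygen on an aromatic ring.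

Within the data shown here, only one measured step bears on this change, and it also alters the group on the amine nitrogen. That step is a 1.6-fold higher number from compound 1 to compound 2 (0.22 log units; within the scatter), so swapping tert-butyl for 2-hydroxyethyl moved the number by no more than the scatter. Among the measured compounds shown here, no measured compound carries a ring on this nitrogen, so a single small step is thin evidence.

In this assay the expected change is therefore none beyond the scatter, an estimated 1.4-fold lower number from compound 2 to compound 3 (0.15 log units; within the scatter). Compound 3 is expected at 1100 nM, with an estimated range from 450 nM to 2700 nM.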

Compound 3, half-maximal inhibitory concentration: 1080 nM
Compound 3: the middle estimate sits 1.0-fold (0.01 log units) above what was measured, and the stated range covers the measured number.
By their numbers in this assay, from the lowest: compounds 1, 3 and 2 (each within the scatter of the next).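

Among these compounds, compound 3 puts a ring on this amine nitrogen for the first time, and its entering group has a six-membered ring and no hydrogen-bond donors. Even so, this assay shows a 1.4-fold lower number from compound 2 to compound 3 (0.16 log units; within the scatter) and a 1.1-fold higher number from compound 1 to compound 3 (0.06 log units; within the scatter). At this position, the cyclohexyl(methyl)amino, (tert-butyl)amino and (2-hydroxyethyl)amino groups therefore cannot be told apart, and nothing available explains why they read alike.

Going by these compounds, all three compounds carry an amine nitrogen on the same 3-carbon propyl chain, so it remains open whether a chain ending in a carboxylic acid or a simple hydroxyl, with no nitrogen at all, would read the same. A longer chain between the ring oxygen and the nitrogen, or a nitrogen held inside a piperidine ring, also remains untested among these compounds.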